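The compounds below may be only part of what the source reports. "The series", "measured", "known", "first", "only" and "open" are said of these compounds alone.

In a functional assay on MV4-11 cells (Homo sapiens) for antiproliferative activity, read by CCK-8 assay, with a stated time of 72 h (on this read-out higher numbers stand for weaker inhibition and lower numbers for stronger inhibition), compound 1 (`Cn1cc(-c2ccccc2Oc2ccccc2)c2cc(C(=O)NCCCCCCC(=O)NO)[nH]c2c1=O`) gives 180 nM and compound 2 (`Cc1cc(F)cc(C)c1Oc1ccc(C(C)(C)O)cc1-c1cn(C)c(=O)c2[nH]c(C(=O)NCCCCCCC(=O)NO)cc12`) gives 300 nM (the two values lie within the scatter of each other). Compound 3 (`Cn1cc(-c2ccccc2Oc2ccccc2)c2cc(C(=O)NCc3ccc(C(=O)NO)cc3)[nH]c2c1=O`) keeps the core of compound 1 but carries 4-(hydroxycarbamoyl)phenyl in place of 5-(hydroxycarbamoyl)pentyl on a saturated chain carbon bound to an amide-type nitrogen. Among the compounds with values here, no measured pair shows this change, so no shift beyond the scatter is expected in this assay and no direction is favoured. The estimated move is a 1.1-fold higher number from compound 1 to compound 3 (0.05 log units; within the scatter) (a weakly grounded expectation). For compound 3 the estimate is 200 nM (expected range 70 nM to 600 nM).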

Compound 3, half-maximal inhibitory concentration: 570 nM
For compound 3 the middle estimate is 2.9-fold (0.45 log units) below the measured one, and the stated range covers the measured number.
By their numbers in this assay, from the lowest: compounds 1, 2 and 3 (each within the scatter of the next, the first and the last beyond it).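

In this assay, 4-(hydroxycarbamoyl)phenyl in place of 5-(hydroxycarbamoyl)pentyl on a saturated chain carbon bound to an amide-type nitrogen gives a 3.2-fold higher number from compound 1 to compound 3 (0.50 log units; beyond the scatter), so this position is sensitive to the change, though compound 3 still shows activity in the nanomolar range. Nothing measured accounts for the shift. Open, as far as these compounds go, is whether a longer chain such as 7-(hydroxycarbamoyl)heptyl would fare differently from 5-(hydroxycarbamoyl)pentyl. Also open, from the compounds shown here alone, is whether the same swap on the core of compound 2 would give a step of similar size.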